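This account rests on a few compounds, and the source may have more. Where it says the series, first, only, none or still open, it means among the compounds named here.

In a functional assay on DU-145 cells (Homo sapiens) for inhibition, read by trypan blue exclusion, with a stated time of 96 h (on this read-out higher numbers stand for weaker inhibition of growth and lower numbers for stronger inhibition of growth), compound 1 `Cc1ccc(S/C(=C/c2cc(Cl)cc(Cl)c2Cl)C(=O)c2ccc(Cl)cc2)cc1` gives 50000 nM, compound 2 `COc1ccc(/C=C(/Sc2ccc(C)cc2)C(=O)c2ccc(Cl)cc2)cc1O` gives 1000 nM and compound 3 `COc1ccc(/C=C(\C(=O)c2ccc(Cl)cc2)S(=O)(=O)c2ccc(Br)cc2)cc1O` gives 10000 nM. Compound 2 therefore holds the lowest number of the three, and its steps to the other two lie beyond the scatter. Compound 4 `Cc1ccc(S/C(=C/c2cc(C)cc(C)c2)C(=O)c2ccc(Cl)cc2)cc1` has not yet been measured. It differs from compound 2 by one change: 3,5-dimethylphenyl in place of 3-hydroxy-4-methoxyphenyl on a double-bonded chain carbon bound to a double-bonded chain carbon. 3,5-dimethylphenyl takes the place of 3-hydroxy-4-methoxyphenyl on a double-bonded chain carbon bound to a double-bonded chain carbon.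

The most relevant evidence is the large step at that same place, a 50-fold lower number from compound 1 to compound 2 (1.70 log units; beyond the scatter), where 3-hydroxy-4-methoxyphenyl came in for 2,3,5-trichlorophenyl. The modest step of a 10-fold higher number from compound 2 to compound 3 (1.00 log units; beyond the scatter) lies at a different place and bears on this change only loosely. Compound 4 gives up the same 3-hydroxy-4-methoxyphenyl, so a clearly higher number is expected in this assay, though this rests on a single pair. The expected step is a 20-fold higher number from compound 2 to compound 4 (1.30 log units; beyond the scatter). For compound 4 the estimated value is 20000 nM, within an expected range of 5000 nM to 60000 nM.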

Compound 4, concentration for 50% growth inhibition: 50000 nM
Estimate against measurement, compound 4: 2.5-fold (0.40 log units) below; low and high end bracket the measured number.
By their numbers in this assay, from the lowest: compound 2; then compound 3; then compounds 1 and 4 (each within the scatter of the next).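

In this assay, among these compounds, putting 3,5-dimethylphenyl on the double-bonded chain carbon in place of 3-hydroxy-4-methoxyphenyl gives a 50-fold higher number from compound 2 to compound 4 (1.70 log units; beyond the scatter), so the single earlier pair at this place now has a second pair with it, this time with an entering group made of carbon only. The two groups that lack the oxygen atoms of 3-hydroxy-4-methoxyphenyl do not separate here, with no change at the digits printed from compound 1 to compound 4 (within the scatter), although one carries chlorine and the other methyl. Nothing at hand gives a reason for the standing of 3-hydroxy-4-methoxyphenyl at this place.

The compounds shown leave open whether 3-hydroxyphenyl or 4-methoxyphenyl alone would read like compound 2 or like compound 4, and where an aminophenyl group would fall at this place. Also open, going by these compounds, is whether 3,5-dimethylphenyl would give a step of this size alongside the (4-bromophenyl)sulfonyl of compound 3.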